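A few compounds are considered here, and "the series" means these few. Any claim that something is new, unique, unknown or untested is made for them only; others in the source may bear on it.

Working notes on the series.

Of the compounds shown here, three have been measured. Compound 1 `CC(C)CCn1c(Cn2c(=O)n(C(C)C)c3ccccc32)nc2c(CN)cccc21`, compound 2 `CC(C)CCn1c(Cn2c(=O)n(C(C)C)c3ccccc32)nc2cc(CN)ccc21` and compound 3 `CC(C)CCn1c(Cn2c(=O)n(C(C)C)c3ccccc32)nc2cc(CO)ccc21` share one core; compound 4 `CC(C)CCn1c(Cn2c(=O)n(C(C)C)c3ccccc32)nc2c(CO)cccc21` is the fourth member and has not been measured. The difference between the cores of compound 1 and compound 2 is not broken down here: the two have the same atoms, joined differently.

In an ADME assay on HEp-2 cells (Homo sapiens) for cytotoxicity (on this read-out higher numbers stand for lower toxicity in this test and lower numbers for higher toxicity in this test), compound 1 gives 7000 nM, compound 2 gives 3920 nM and compound 3 gives 31600 nM. The numbers of compound 1 and compound 2 lie within the scatter of each other, so no order between them is read. From compound 2 to compound 3 the change hydroxy in place of amino on a saturated chain carbon bound to an aromatic carbon gives an 8.1-fold higher number from compound 2 to compound 3 (0.91 log units; beyond the scatter).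

The same change is made from compound 1 to compound 4: hydroxy in place of amino on a saturated chain carbon bound to an aromatic carbon. The place is worded identically for both pairs, so the change is taken as the same one, carried on a different core. Within the data shown here, the only guide to its size is the single step seen from compound 2 to compound 3, because an 8.1-fold higher number from compound 2 to compound 3 (0.91 log units; beyond the scatter) is the one such step in this set. A step of the same kind is therefore expected from compound 1 to compound 4, a 5.7-fold higher number from compound 1 to compound 4 (0.76 log units; beyond the scatter), tempered somewhat since one occurrence is a thin basis and the cores are not the same.

On that basis compound 4 is estimated at 40000 nM in this assay, with a range expected from 12000 nM to 130000 nM.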

Compound 4, half-maximal cytotoxic concentration: 22000 nM
Compound 4: the middle estimate sits 1.8-fold (0.26 log units) above what was measured; the range from low to high includes it.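

In this assay, hydroxy in place of amino on a saturated chain carbon bound to an aromatic carbon gives a 3.1-fold higher number from compound 1 to compound 4 (0.50 log units; beyond the scatter), so the change raises the number on the core of compound 1, as it does on the core of compound 2. Set side by side, the two steps cannot be told apart in size: the same change on two cores in this assay, an 8.1-fold higher number (0.91 log units; beyond the scatter) from compound 2 to compound 3 and a 3.1-fold higher number (0.50 log units; beyond the scatter) from compound 1 to compound 4, 2.6-fold (0.41 log units) apart, within the scatter of two such steps. In this series, the change therefore carries from one core to the other in direction and, within the scatter, in size, but two pairs do not establish a fixed step for the change, and they show neither why the number rises nor that the same would hold on any further core.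

Still open, going by these compounds, is how a carboxylic acid, a methoxymethyl group or a longer chain ending in an amine would read in this assay on either core. Also open, on these data alone, is whether aminomethyl to hydroxymethyl would give a step of this direction and size on a core that departs further from these two.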